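A thioamide-to-carboxy exchange on the pyridazinone chain

The source may report more compounds than this note shows. Statements on the series, on what has been measured and on what is new or still open speak of the compounds shown alone.

Compound 1: `CC/N=C(\S)CCn1nc(-c2ccccc2)ccc1=O` — 50.3%
Compound 2: `CC(CC(=N)S)N1N=C(c2ccccc2)CCC1=O` — 9.2%

Two compounds have a measured number in a functional assay on the whole organism (stomach) for inhibition, with Rattus norvegicus as the target, at a dose of 100 mg/kg by the intraduodenal route; on this read-out higher numbers stand for more inhibition at the one dose given (going by the name of the read-out) and lower numbers for less inhibition. Compound 1, `CC/N=C(\S)CCn1nc(-c2ccccc2)ccc1=O`, gives 50.3% in this assay, the higher of the two values. Compound 2, `CC(CC(=N)S)N1N=C(c2ccccc2)CCC1=O`, gives 9.2% in this assay, a number that lies far below that of compound 1, well beyond the scatter of repeated measurements. Compound 2 differs from compound 1 in more than one place, so the two values say only what each compound does on its own and no single change can be read from them.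

Compound 3, `O=C(O)CCn1nc(-c2ccccc2)ccc1=O`, has not yet been measured. It differs from compound 1 in one place: a group of 3 heavy atoms (1 carbon, 2 oxygen; no ring) in place of a group of 5 heavy atoms (3 carbon, 1 nitrogen, 1 sulfur; no ring), on a saturated chain carbon, two bonds along the chain from an aromatic nitrogen. Among the compounds with values here, no pair of measured compounds shows such an exchange, so there is nothing to lean on but the value of compound 1 itself. With a carboxy taking the place of the larger group, a step from compound 1 to compound 3 of a number 20.3 percentage points lower from compound 1 to compound 3 (beyond the scatter) is expected, downward and beyond the scatter, though with wide uncertainty. Compound 3 is therefore estimated at 30%, with a range from 5% to 58%.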

Compound 3, a percentage reported as inhibition, in the whole organism at one dose (the size of the read-out at that dose, not a potency): 26.1%
Compound 3: the middle estimate sits 3.9 percentage points above what was measured, and the stated range covers the measured number.
By their numbers in this assay, from the lowest: compound 2; then compound 3; then compound 1.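

In this assay, within the data shown here, the exchange of the group of 5 heavy atoms for a carboxy, on a saturated chain carbon, two bonds along the chain from an aromatic nitrogen, comes with a number 24.2 percentage points lower from compound 1 to compound 3 (beyond the scatter) and gives the first reading of a single change at this position. The group on this chain therefore matters to the size of the inhibition at the one dose given, yet the larger group is not needed for all of it, as compound 3 still gives 26.1% with the carboxy in its place. Nothing measured here bears on why the number falls with this exchange.

Among these compounds, with only this one exchange at the position, it stays open whether the fall goes with the sulfur and nitrogen of the group that leaves, with its ethyl end, or with the carboxy that enters, and an amide, a methyl ester or a longer chain ending in the carboxy would help to separate these readings. Since each number comes from a single dose, the compounds shown also leave open how compound 1 and compound 3 would compare across a range of doses.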